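Dichlorophenoxy to Methoxyphenylsulfanyl on a Shared Core

The compounds below may be only part of what the source reports. "The series", "measured", "known", "first", "only" and "open" are said of these compounds alone.

Compound 1, `Nc1cc(N)c2nc(-c3ccccc3)c(Oc3ccc(Cl)c(Cl)c3)nc2c1`: < 100000 nM
Compound 2, `COc1cc(CNc2nc3cc(N)cc(N)c3nc2-c2ccccc2)cc(OC)c1OC`: < 50200 nM
Compound 3, `COc1ccc(CNc2nc3cc(N)cc(N)c3nc2-c2ccccc2)cc1OC`: < 100000 nM

In a functional assay on A549 cells (Homo sapiens) for inhibition, read by sulforhodamine B assay, with a stated time of 48 h (a higher number here means that more compound is tolerated, a lower number that less compound is tolerated), compound 1 gives < 100000 nM, which is a limit of the assay rather than a number. Compound 2 gives < 50200 nM, also a limit. Compound 3 gives < 100000 nM, again a limit. Within the data shown here, the only pair that differs in one place is compound 2 and compound 3, and there a step that the two limits leave unreadable from compound 2 to compound 3; the two limits leave its size unreadable. Two of the three values sit at the limit of < 100000 nM in this assay, at which 2 of the 3 values shown sit, one at the limit of < 50200 nM in this assay, at which 1 of the 3 values shown sits.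

Compound 4, `COc1ccc(Sc2nc3cc(N)cc(N)c3nc2-c2ccccc2)cc1`, is yet to be measured in this assay. It differs from compound 1 by (4-methoxyphenyl)sulfanyl in place of 3,4-dichlorophenoxy on an aromatic carbon. Among the measured compounds shown here, no measured step in this set involves a change of that kind, and every value shown is a limit, so nothing here gives a direction or a size for the step to compound 4. The account therefore expects a value near the limits seen so far. For compound 4 the estimate is 80000 nM, with a range from 20000 nM to 300000 nM, which would mean an expected step that the limit leaves unreadable from compound 1 to compound 4.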

Compound 4, concentration lethal to 50% of the cells: < 100000 nM
Compound 4: no number, only a limit; the forecaster's own chance of this, stated with the estimate: 75%; the middle value does not contradict the limit.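

Among these compounds, compound 1 and compound 4 are both reported in this assay only as limits, so no step between them can be read. The compounds shown leave open whether (4-methoxyphenyl)sulfanyl in place of 3,4-dichlorophenoxy shifts the value at all, and in which direction.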